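The source may hold more compounds than are shown below. What is called first, only, known or untested is meant among the compounds shown, and "the series" means these compounds.

Measured so far:
compound 1, `CC(O)CC#Cc1c(Cl)c2c(Cl)cc(C(N)=O)nc2n1[C@H]1CCCNC1`, gives 48 nM in a functional assay on KG-1 cells (Homo sapiens) for antiproliferative activity; on this read-out higher numbers stand for an effect only at larger amounts of compound and lower numbers for an effect already at smaller amounts.
compound 2, `CN1CC(C#Cc2c(Cl)c3c(Cl)cc(C(N)=O)nc3n2[C@H]2CCCNC2)CC1=O`, gives 155 nM in this assay.
compound 3, `NC(=O)c1cc(Cl)c2c(Cl)c(C#CCN3CCCC3=O)n([C@H]3CCCNC3)c2n1`, gives 178 nM in this assay.

Compound 1 holds the lowest number of the three. Two steps lead away from it, each changing only the group on the triple-bonded carbon: a 3.2-fold higher number from compound 1 to compound 2 (0.51 log units; beyond the scatter) and a 3.7-fold higher number from compound 1 to compound 3 (0.57 log units; beyond the scatter). Between the two larger groups the difference is small: a 1.1-fold higher number from compound 2 to compound 3 (0.06 log units; within the scatter).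

Compound 4, `NC(=O)c1cc(Cl)c2c(Cl)c(C#CC3CCOCC3)n([C@H]3CCCNC3)c2n1`, has not yet been measured. Its change from compound 1 is oxan-4-yl in place of 2-hydroxypropyl on a triple-bonded carbon. The two measured steps bear on it directly, since each of them also removed the 2-hydroxypropyl group and put a ring-bearing group in its place, and each raised the number in this assay by a modest amount beyond the scatter. The oxan-4-yl group likewise brings a six-membered non-aromatic ring and gives up the hydrogen-bond donor of the 2-hydroxypropyl group. A modest rise in the number is therefore expected, a 2.5-fold higher number from compound 1 to compound 4 (0.40 log units; beyond the scatter), in the same direction as the two measured steps. Compound 4 is estimated to give 120 nM in this assay, with a range from 50 nM to 280 nM.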

Compound 4, half-maximal effective concentration: 69 nM
Estimate against measurement, compound 4: 1.7-fold (0.24 log units) above; the range from low to high includes it.
By their numbers in this assay, from the lowest: compounds 1 and 4 (each within the scatter of the next); then compounds 2 and 3 (each within the scatter of the next).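

The new step (a 1.4-fold higher number from compound 1 to compound 4 (0.16 log units; within the scatter)) shows that at this triple-bonded carbon, oxan-4-yl, with its six-membered non-aromatic ring and 0 hydrogen-bond donors, can stand in for 2-hydroxypropyl without a change that rises above the scatter in this assay. A ring on this carbon is therefore not enough on its own to raise the number: 1-methyl-5-oxopyrrolidin-3-yl and (2-oxopyrrolidin-1-yl)methyl also bring a ring, and oxan-4-yl in their place gives two steps beyond the scatter (a 2.2-fold lower number from compound 2 to compound 4 (0.35 log units; beyond the scatter); a 2.6-fold lower number from compound 3 to compound 4 (0.41 log units; beyond the scatter)). Nothing measured here explains why oxan-4-yl and the two groups containing a ring carbonyl differ in this way.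

The compounds shown leave open what the ring oxygen of oxan-4-yl contributes, a question that a plain cyclohexyl group would address, and whether the hydroxyl of 2-hydroxypropyl matters, which a simple propyl chain would test. They also say nothing about how a ring amine such as piperidin-4-yl, a carboxylic acid or a longer chain would behave on this triple-bonded carbon.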